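Swapping Bromo for Methyl in a Cytotoxicity Series

A few compounds are considered here, and "the series" means these few. Any claim that something is new, unique, unknown or untested is made for them only; others in the source may bear on it.

Compound 1 `COc1cc(-c2nnc(SCc3cccc(Br)c3)o2)ccc1O` gives 382000 nM in an ADME assay on cells (Mus musculus, strain BALB/c) for cytotoxicity, read by MTT assay, with a stated time of 24 h; on this read-out higher numbers stand for lower toxicity in this test and lower numbers for higher toxicity in this test.
Compound 2 `COc1cc(-c2nnc(SCc3ccccc3Br)o2)ccc1O` gives 363000 nM in this assay.

Compound 2 stands alongside compound 1: the step of a 1.1-fold lower number from compound 1 to compound 2 (0.02 log units; within the scatter) lies within the scatter, so the two cannot be told apart on these numbers.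

Compound 3 `COc1cc(-c2nnc(SCc3ccccc3C)o2)ccc1O` differs from compound 2 by methyl in place of bromo on an aromatic carbon. Going by the values given here, the only measured step, a 1.1-fold lower number from compound 1 to compound 2 (0.02 log units; within the scatter), moves the bromo rather than exchanging it, and shows nothing beyond the scatter, so it bears on this change only loosely. No step beyond the scatter is expected, and the expected step is a 1.0-fold higher number from compound 2 to compound 3 (0.02 log units; within the scatter). Compound 3 is estimated at 380000 nM, within 150000 nM to 900000 nM.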

Compound 3, half-maximal cytotoxic concentration: 592000 nM
For compound 3 the middle estimate is 1.6-fold (0.19 log units) below the measured one, and the stated range covers the measured number.
By their numbers in this assay, from the lowest: compounds 2, 1 and 3 (each within the scatter of the next).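

Exchanging bromo for methyl on this aromatic carbon, ortho to a large group, brings a 1.6-fold higher number from compound 2 to compound 3 (0.21 log units; within the scatter) in this assay and so replacing the bromo, like moving it, does not separate the compounds. Going from 3-bromophenyl to 2-methylphenyl brings a 1.5-fold higher number from compound 1 to compound 3 (0.19 log units; within the scatter) and this change cannot separate them either. No measurement at hand offers an explanation for these numbers.

From the compounds shown here alone, whether an amine or a carboxylic acid on this aromatic carbon would shift the number beyond the scatter remains open. So does the effect of a longer chain in place of the methyl.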